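The source may hold more compounds than are shown below. What is called first, only, known or untested is meant among the compounds shown, and "the series" means these compounds.

Measured in an ADME assay on HCT-116 cells (Homo sapiens) for cytotoxicity, read by CellTiter-Glo, with a stated time of 72 h; a lower number here means a stronger inhibitor, a higher number a weaker inhibitor:
compound 1 `CC1CCN(C2CCN(S(=O)(=O)c3cccc(N)c3)CC2)CC1`: > 5000 nM
compound 2 `COc1ccccc1-c1cccc(S(=O)(=O)N2CCC(N3CCC(C)CC3)CC2)c1`: > 5000 nM
compound 3 `CC1CCN(C2CCN(S(=O)(=O)c3cccc(-c4ccccc4F)c3)CC2)CC1`: > 5000 nM

All three entries are limits, not numbers. Compound 1 stands only at its limit of > 5000 nM. For the measured compounds named here, the series so far shows (the limit of > 5000 nM in this assay, at which 3 of the 3 values shown sit).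

Compound 4 `CC1CCN(C2CCN(S(=O)(=O)c3nccn3C)CC2)CC1` carries one change: 1-methyl-1H-imidazol-2-yl in place of 3-aminophenyl on a sulfonyl sulfur.

Three measured steps are at hand: a step that the two limits leave unreadable from compound 1 to compound 2, a step that the two limits leave unreadable from compound 1 to compound 3 and a step that the two limits leave unreadable from compound 2 to compound 3. None gives a size, and all three change a group on an aromatic carbon, not the group on the sulfonyl sulfur. No step beyond the scatter is therefore expected in this assay, and no direction can be given.

The expected step is a step that the limit leaves unreadable from compound 1 to compound 4.

Compound 4 is estimated at 7000 nM, with an expected range of 3000 nM to 20000 nM.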

Compound 4, half-maximal inhibitory concentration: > 10000 nM
Compound 4: a limit, no number (the forecaster's own chance of this, stated with the estimate: 90%); middle value at least 1.4-fold (0.15 log units) away from the limit.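

For the compounds shown here, compound 1 and compound 4 both stand as limits, not numbers, and no step between them can be read. The compounds shown leave open whether any of them has a measurable half-maximal inhibitory concentration in this assay, and whether the group on the sulfonyl sulfur affects it.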